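The source may hold more compounds than are shown below. What is called first, only, known or untested is meant among the compounds shown, and "the series" means these compounds.

Compound 1, drawn as `Nc1ccc(C(=O)/C=C/c2ccc(Cl)cc2)cc1`, stands at the top of three numbers here: in a functional assay on the whole organism (strain albino) for inhibition, with Rattus norvegicus as the target, read by paw edema, with stated times of 30 min and 3 h, at a dose of 100 mg/kg by the oral route (a higher number here means more inhibition at the dose given (going by the name of the read-out), a lower number less inhibition), compound 1 gives 60%. Compound 3, `COc1ccc(/C=C/C(=O)c2ccc(NC(=O)CO[N+](=O)[O-])cc2)cc1`, gives 53%, a number within the scatter of compound 1, so no order between the two can be claimed. Compound 2, `O=C(CBr)Nc1ccc(C(=O)/C=C/c2ccco2)cc1`, gives 41%, and this gap to compound 1 lies beyond the scatter. Compound 4, `CC(Br)C(=O)Nc1ccc(C(=O)/C=C/c2ccc(Cl)cc2)cc1`, has not yet been measured; it differs from compound 1 by one change, ((1-bromoethyl)carbonyl in place of hydrogen on a nitrogen on an aromatic ring). Compound 2 and compound 3, each carrying an acyl group on the same nitrogen, both lie at or below compound 1. On that basis the step of a number 11 percentage points lower from compound 1 to compound 4 (beyond the scatter) is expected to be small and downward. Compound 4 is therefore estimated at 49%, within 36% to 62%.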

Compound 4, a percentage reported as inhibition, in the whole organism at one dose (the size of the read-out at that dose, not a potency): 59%
Beside the measured number, compound 4's estimate is 10 percentage points below it; measured number inside the range.
By their numbers in this assay, from the lowest: compound 2; then compounds 3, 4 and 1 (each within the scatter of the next).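

In this assay, within the data shown here, the change from amino to ((1-bromoethyl)carbonyl)amino gives a number 1 percentage points lower from compound 1 to compound 4 (within the scatter), the only direct reading of a change on this nitrogen on an aromatic ring. On the core of compound 1, this nitrogen therefore carries the (1-bromoethyl)carbonyl group in place of hydrogen with no shift that can be told from the scatter. No measurement shown offers a reason for this result. The compounds shown leave open whether a propanoyl group, which has no bromine, would read the same on this nitrogen. They also leave open how a longer acyl chain or one ending in a carboxylic acid would read there.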